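A Pyridin-4-yl Variant of Compound 1

The source may hold more compounds than are shown below. What is called first, only, known or untested is meant among the compounds shown, and "the series" means these compounds.

Compound 1 `CC(C)=CCC/C(C)=C/CC/C(C)=C/CC[C@@H]1[C@@]2(C)CC/C(=N\OCc3cn(-c4ccc(F)cc4)nn3)C(C)(C)[C@@H]2CC[C@@]1(C)O` was tested in a functional assay on HeLa cells (Homo sapiens) for cytotoxicity, read by MTT assay, with a stated time of 48 h (on this read-out higher numbers stand for weaker inhibition and lower numbers for stronger inhibition), and gave 21400 nM, the highest of the three measured numbers. Compound 2 `CC(C)=CCC/C(C)=C/CC/C(C)=C/CC[C@@H]1[C@@]2(C)CC/C(=N\OCc3cn(-c4ccccc4C#N)nn3)C(C)(C)[C@@H]2CC[C@@]1(C)O` gave 21200 nM, and compound 3 `CC(C)=CCC/C(C)=C/CC/C(C)=C/CC[C@@H]1[C@@]2(C)CC/C(=N\OCc3cn(-c4cccc([N+](=O)[O-])c4)nn3)C(C)(C)[C@@H]2CC[C@@]1(C)O` gave 18400 nM. The steps from compound 1 were a 1.0-fold lower number from compound 1 to compound 2 (0.00 log units; within the scatter) and a 1.2-fold lower number from compound 1 to compound 3 (0.07 log units; within the scatter), and between the other two the step was a 1.2-fold lower number from compound 2 to compound 3 (0.06 log units; within the scatter). Compound 4 `CC(C)=CCC/C(C)=C/CC/C(C)=C/CC[C@@H]1[C@@]2(C)CC/C(=N\OCc3cn(-c4ccncc4)nn3)C(C)(C)[C@@H]2CC[C@@]1(C)O` differs from compound 1 by pyridin-4-yl in place of 4-fluorophenyl on an aromatic nitrogen. Each measured step changes the same aromatic group and none moved beyond the scatter, so the change to compound 4 is expected to give no step beyond the scatter in this assay. Compound 4 is therefore estimated at 21000 nM, with a range from 11000 nM to 40000 nM, an expected step of a 1.0-fold lower number from compound 1 to compound 4 (0.01 log units; within the scatter).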

Compound 4, half-maximal inhibitory concentration: 18800 nM
Compound 4: the middle estimate sits 1.1-fold (0.05 log units) above what was measured; low and high end bracket the measured number.
By their numbers in this assay, from the lowest: compounds 3, 4, 2 and 1 (each within the scatter of the next).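

In this assay, compound 4 puts a six-membered aromatic ring with a hetero atom on this nitrogen, where compounds 1, 2 and 3 all carry a ring of carbon only, and the number stays within the scatter: a 1.1-fold lower number from compound 1 to compound 4 (0.06 log units; within the scatter), a 1.1-fold lower number from compound 2 to compound 4 (0.05 log units; within the scatter) and a 1.0-fold higher number from compound 3 to compound 4 (0.01 log units; within the scatter). Across these four compounds, then, the hetero atom in this ring leaves the read-out unmoved, as the substituents on the carbon ring did. No available data bear on why this position responds so little. From the compounds shown here alone, whether an amine, a carboxylic acid or a longer alkyl chain on this nitrogen, in place of the aromatic ring, would shift the number stays open.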